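The source may hold more compounds than are shown below. What is called first, only, known or untested is meant among the compounds shown, and "the series" means these compounds.

Series notes. In an assay on HEK293 cells for binding affinity to 5-hydroxytryptamine receptor 7 (Homo sapiens), read by radioligand binding, tested at 1 uM (a higher number here means more inhibition at the concentration tested (going by the name of the read-out), a lower number less inhibition), compound 1 `CN1CCCN(CCn2ccc3ccc(Cl)cc32)CC1` gives 85%. Compound 2 `CN1CCCN(CCn2ccc3ccc(N)cc32)CC1` gives 0%, and compound 3 `C#Cc1ccc2ccn(CCN3CCCN(C)CC3)c2c1` gives 79%. Compound 3 thus sits close to compound 1, the gap being a number 6 percentage points lower from compound 1 to compound 3 (within the scatter), and far from compound 2, the gap being a number 79 percentage points higher from compound 2 to compound 3 (beyond the scatter). Compound 4 `CN1CCCN(CCn2ccc3ccc(C(C)(C)O)cc32)CC1` is not yet measured; the change is 1-hydroxy-1-methylethyl in place of ethynyl on an aromatic carbon. Both measured steps at this aromatic carbon bear on it: chloro to ethynyl moved little, a number 6 percentage points lower from compound 1 to compound 3 (within the scatter), whereas chloro to amino removed inhibition entirely, a number 85 percentage points lower from compound 1 to compound 2 (beyond the scatter). A substituent unlike either chloro or ethynyl has so far meant a large loss, so a sizeable fall in this assay is expected, though not necessarily a complete one. Compound 4 is estimated at 30%, range 5% to 65%, an expected step of a number 49 percentage points lower from compound 3 to compound 4 (beyond the scatter).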

Compound 4, a percentage reported as inhibition, at one concentration (the size of the read-out at that concentration, not a potency): 6%
The estimate for compound 4 lay 24 percentage points above the measured number; measured number inside the range.
By their numbers in this assay, from the lowest: compounds 2 and 4 (each within the scatter of the next); then compounds 3 and 1 (each within the scatter of the next).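

At this aromatic carbon in this assay, 1-hydroxy-1-methylethyl groups with amino rather than with chloro or ethynyl: a number 73 percentage points lower from compound 3 to compound 4 (beyond the scatter) and a number 79 percentage points lower from compound 1 to compound 4 (beyond the scatter), whereas a number 6 percentage points higher from compound 2 to compound 4 (within the scatter). The near-total loss is therefore not peculiar to amino, and the position now separates two substituents that keep inhibition from two that do not. Nothing available accounts for this split. From the compounds shown here alone, whether bromo or nitrile at this carbon would stay with chloro and ethynyl remains open. So does whether methoxy or a carboxylic acid would fall with amino and 1-hydroxy-1-methylethyl.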